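The source may report more compounds than this note shows. Statements on the series, on what has been measured and on what is new or still open speak of the compounds shown alone.

In a functional assay on NCI-H460 cells (Homo sapiens) for cytotoxicity (a lower number here means a stronger inhibitor, a higher number a weaker inhibitor), compound 1 `CCCCCCCC[C@@H](C/C=C/CCC(=O)NC/C(=C/Cl)[C@]12O[C@H]1[C@H](OC(C)=O)CCC2=O)OC` gives 4000 nM and compound 2 `CCCCCCCC[C@@H](C/C=C/CCC(=O)NC/C(=C/Cl)[C@]12O[C@H]1[C@H](O)CCC2=O)OC` gives 4000 nM as well, so compound 2 stands level with compound 1. Compound 3 `CCCCCCCC[C@@H](C/C=C/CCC(=O)NC/C(=C/Cl)C1=CCC[C@@H](OC(C)=O)C1=O)OC` has not been measured, and the change leading to it is a group of 11 heavy atoms (8 carbon, 3 oxygen; one six-membered non-aromatic ring of carbon only) in place of a group of 9 heavy atoms (6 carbon, 3 oxygen; one three-membered non-aromatic ring with 1 hetero atom, one six-membered non-aromatic ring of carbon only), on a double-bonded chain carbon bound to a double-bonded chain carbon and a saturated chain carbon on a double-bonded chain carbon. Among the compounds with values here, the one measured step of no change at the digits printed from compound 1 to compound 2 (within the scatter) only puts hydrogen in place of acetyl on an oxygen and leaves the three-membered ring intact, so it offers weak guidance. A modest weakening in this assay is expected, though no measured step sizes it. The expected step of a 1.8-fold higher number from compound 2 to compound 3 (0.24 log units; within the scatter) is only an estimate from this change. Compound 3 is estimated at 7000 nM with a range from 2500 nM to 25000 nM for this expectation.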

Compound 3, half-maximal inhibitory concentration: 4000 nM
Compound 3: the middle estimate sits 1.8-fold (0.24 log units) above what was measured, within the range that was stated.
By their numbers in this assay, from the lowest: compounds 1, 2 and 3 (each within the scatter of the next).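

In this assay, replacing the group with the three-membered ring by the larger group with only the six-membered ring gives no change at the digits printed from compound 2 to compound 3 (within the scatter). Compounds 1 and 2 both kept the three-membered ring, whereas this step shows that cytotoxicity at this level does not depend on that ring being present. No further measurement bears on this result. On these data alone, whether the acetyl group matters without the three-membered ring remains open. So does whether an amine or a carboxylic acid on this double-bonded chain carbon would change the number.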